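The source may report more compounds than this note shows. Statements on the series, on what has been measured and on what is new or still open speak of the compounds shown alone.

Working notes on the series. Compound 3 `C[C@@H](Cn1ccc(-c2ccc(C#N)c(Cl)c2)n1)Nc1ccccn1` is the point of departure. In a functional assay on LNCaP cells (Homo sapiens) for antiproliferative activity, read by CCK-8 assay, with a stated time of 6 days (a higher number here means a weaker inhibitor, a lower number a stronger inhibitor), compound 3 gives 1110 nM, the lowest number among the two real numbers available. Compound 1 `C[C@@H](Cn1ccc(-c2ccc(C#N)c(Cl)c2)n1)NC(=O)c1ccccc1` gives 1830 nM in this assay, and the step of a 1.6-fold lower number from compound 1 to compound 3 (0.22 log units; within the scatter) stays within the scatter. Compound 2 `C[C@@H](Cn1ccc(-c2ccc(C#N)c(Cl)c2)n1)NS(=O)(=O)c1cn(C)cn1` returns only a limit in this assay, > 30000 nM, as noted in the limit of > 30000 nM in this assay, at which 1 of the 3 values shown sits.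

Compound 4 `Cc1ccnc(N[C@@H](C)Cn2ccc(-c3ccc(C#N)c(Cl)c3)n2)n1` differs from compound 3 by 4-methylpyrimidin-2-yl in place of pyridin-2-yl on an amine nitrogen. For the measured compounds named here, the only steps that bear on this change are those swapping one neutral aromatic group for another on the same amine nitrogen: a 1.6-fold lower number from compound 1 to compound 3 (0.22 log units; within the scatter) is within the scatter, while an at least 16-fold higher number from compound 1 to compound 2 (1.21 log units; beyond the scatter) and an at least 27-fold lower number from compound 2 to compound 3 (1.43 log units; beyond the scatter) are large but concern a sulfonyl group, which is not involved here. A six-membered aromatic ring stays in place, with one more nitrogen and a methyl group added, so no step beyond the scatter is expected, in either direction.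

Compound 4 is therefore expected to give 900 nM in this assay, between 300 nM and 3000 nM, which means an estimated step of a 1.2-fold lower number from compound 3 to compound 4 (0.09 log units; within the scatter).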

Compound 4, half-maximal inhibitory concentration: 1330 nM
Beside the measured number, compound 4's estimate is 1.5-fold (0.17 log units) below it, and the stated range covers the measured number.
By their numbers in this assay, from the lowest: compounds 3, 4 and 1 (each within the scatter of the next). At a limit, above all of these: compound 2.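

In this assay, the change gives a 1.2-fold higher number from compound 3 to compound 4 (0.08 log units; within the scatter), so adding a ring nitrogen and a methyl group to the six-membered aromatic ring on this amine nitrogen leaves the number within the scatter. Against the benzoyl group the step is a 1.4-fold lower number from compound 1 to compound 4 (0.14 log units; within the scatter), so the three groups in compounds 1, 3 and 4 give numbers within the scatter of one another. Only the (1-methyl-1H-imidazol-4-yl)sulfonyl group stands apart, with an at least 22-fold lower number from compound 2 to compound 4 (1.35 log units; beyond the scatter), and that step rests on a limit of the assay: the limit of > 30000 nM in this assay, at which 1 of the 4 values shown sits.

On these data alone, the methyl group and the added ring nitrogen enter together, so what each does alone stays open. Also open, as far as these compounds go, is whether another group on this nitrogen, such as a piperidine or a carboxylic acid, would move the number beyond the scatter in either direction.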